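A Methyl Step Repeated on a Pyrrolidinyl Analogue

The source may hold more compounds than are shown below. What is called first, only, known or untested is meant among the compounds shown, and "the series" means these compounds.

Of the compounds shown here, three have been measured in an ADME assay on cells (Hepatocyte, Rattus norvegicus) for metabolic stability, read by HPLC, with a stated time of 30 min, tested at 1 uM; a lower number here means slower removal, a higher number faster removal of the compound. In this assay compound 1 `C[C@H](Nc1c(C(N)=O)nnc2ccc(-c3ccc(OCCCN(C)C)nc3)cc12)c1ccn(C)n1` gives 7 uL/min. Compound 2 `Cc1cn(C)nc1[C@H](C)Nc1c(C(N)=O)nnc2ccc(-c3ccc(OCCCN(C)C)nc3)cc12` differs from compound 1 by methyl in place of hydrogen on an aromatic carbon. In this assay compound 2 gives 12 uL/min, and the step is a 1.7-fold higher number from compound 1 to compound 2 (0.23 log units; within the scatter). Compound 3 `C[C@H](Nc1c(C(N)=O)nnc2ccc(-c3ccc(OCCCN4CCCC4)nc3)cc12)c1ccn(C)n1` carries a different core, and how the two cores differ is given by pyrrolidin-1-yl in place of dimethylamino on a saturated chain carbon, three bonds along the chain from an oxygen on an aromatic ring. In this assay compound 3 gives 4.6 uL/min, with a 1.5-fold lower number from compound 1 to compound 3 (0.18 log units; within the scatter). Compound 3 thus stands with the lowest of the three numbers, but its nearest neighbour is compound 1 within the scatter, and only compound 2 lies beyond it.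

Compound 4 `Cc1cn(C)nc1[C@H](C)Nc1c(C(N)=O)nnc2ccc(-c3ccc(OCCCN4CCCC4)nc3)cc12` has not yet been measured in this assay. It differs from compound 3 by methyl in place of hydrogen on an aromatic carbon. This is the same change that was made from compound 1 to compound 2, and the two descriptions of the place agree word for word, so it counts as the same change made on the other core. The step expected from compound 3 to compound 4 in this assay is a 1.6-fold higher number from compound 3 to compound 4 (0.21 log units; within the scatter), because the same change once gave a 1.7-fold higher number from compound 1 to compound 2 (0.23 log units; within the scatter), a step that itself sits within the scatter. Compound 4 is therefore expected to give about 7.5 uL/min in this assay, with the likely range running from 4 uL/min to 14 uL/min.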

Compound 4, intrinsic clearance in a liver preparation (reported as CLH), per the amount of preparation that the assay uses: 8.1 uL/min
Beside the measured number, compound 4's estimate is 1.1-fold (0.03 log units) below it; the measured number falls inside the stated range.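

In this assay the methyl step on the core that carries pyrrolidin-1-yl reads a 1.8-fold higher number from compound 3 to compound 4 (0.25 log units; within the scatter), and it agrees with the same step on the core that carries dimethylamino: the same change on two cores in this assay, a 1.7-fold higher number (0.23 log units; within the scatter) from compound 1 to compound 2 and a 1.8-fold higher number (0.25 log units; within the scatter) from compound 3 to compound 4, 1.0-fold (0.01 log units) apart, within the scatter of two such steps The exchange of dimethylamino for pyrrolidin-1-yl, read on the compounds that carry the added methyl, reads a 1.5-fold lower number from compound 2 to compound 4 (0.17 log units; within the scatter), and it agrees in the same way with the exchange on the compounds without that methyl: the same change on two cores in this assay, a 1.5-fold lower number (0.18 log units; within the scatter) from compound 1 to compound 3 and a 1.5-fold lower number (0.17 log units; within the scatter) from compound 2 to compound 4, 1.0-fold (0.01 log units) apart, within the scatter of two such steps Within these four compounds, then, each change reads alike on both cores, but every step lies within the scatter, so the agreement does not show that either change truly moves the number, and one pair of cores in one assay gives no rule for the wider series.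

The compounds shown leave open whether a larger group than methyl on that aromatic carbon, such as ethyl or cyclopropyl, would give a step that stands clear of the scatter in this assay. They also leave open how another amine at the end of the chain, such as morpholine or piperidine, or a longer chain between the oxygen and the amine, would read on these cores.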